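A few compounds are considered here, and "the series" means these few. Any claim that something is new, unique, unknown or untested is made for them only; others in the source may bear on it.

Measured so far in a functional assay on A549 cells (Homo sapiens) for antiproliferative activity, read by MTT assay, with a stated time of 48 h; a lower number here means a stronger inhibitor, a higher number a weaker inhibitor:

compound 1 `COc1ccc(C(=O)c2ccc(OC)c3c2OC(C)(C)C=C3)c(NC(=O)CO)c1` gives 80 nM
compound 2 `COc1ccc(C(=O)c2ccc3c(c2)C=CC(C)(C)O3)c(NC(=O)CO)c1` gives 90 nM
compound 3 `COc1ccc(C(=O)c2ccc3c(c2)C=CC(C)(C)O3)c(NC(=O)CN)c1` gives 310 nM

Compound 3 has the highest number of the three, and its gaps to compound 2 and to compound 1 both lie beyond the scatter. Compound 1 and compound 2 sit within the scatter of each other.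

The next compound is compound 4 `CCNCC(=O)Nc1cc(OC)ccc1C(=O)c1ccc2c(c1)C=CC(C)(C)O2`, which differs from compound 3 in one place: ethyl in place of hydrogen on an amine nitrogen. In short, ethyl in place of hydrogen on an amine nitrogen, or amino to ethylamino.

For the measured compounds named here, only one measured step touches this end of the chain: a 3.4-fold higher number from compound 2 to compound 3 (0.54 log units; beyond the scatter). That modest step is a different change, amino in place of hydroxy, so it offers only weak guidance. Going by the values given here, no measured pair shows what substitution on this amine nitrogen does in this assay. Among the compounds with values here, a small move toward a higher number is expected, no larger than that step and possibly not beyond the scatter. The estimated step is a 1.5-fold higher number from compound 3 to compound 4 (0.19 log units; within the scatter). For compound 4 the estimated value is 480 nM, with an expected range of 160 nM to 1400 nM.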

Compound 4, half-maximal inhibitory concentration: 1300 nM
Compound 4: middle estimate off by 2.7-fold (0.43 log units), on the low side, and the stated range covers the measured number.
By their numbers in this assay, from the lowest: compounds 1 and 2 (each within the scatter of the next); then compound 3; then compound 4.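

In this assay this amine nitrogen is not a neutral place for substitution: ethyl in place of hydrogen gives a 4.2-fold higher number from compound 3 to compound 4 (0.62 log units; beyond the scatter) and adds only 2 heavy atoms, with no ring and no net charge. Against the hydroxy end of the chain, ethylamino in place of hydroxy gives a 14-fold higher number from compound 2 to compound 4 (1.16 log units; beyond the scatter) and this large step runs the same way as a 3.4-fold higher number from compound 2 to compound 3 (0.54 log units; beyond the scatter) so the numbers rise from hydroxy to amino to ethylamino, a trend that holds only for compound 2, compound 3 and compound 4 on their shared core. No measurement at hand bears on the reason for this rise.

As far as these compounds go, it remains open whether the number keeps rising with a longer chain such as propyl on this nitrogen, or with a second ethyl on it, or with the nitrogen held in a morpholine ring. Also open, from the compounds shown here alone, is how the amino and ethylamino chains behave on the core of compound 1, which carries an extra methoxy group and whose hydroxy compound lies within the scatter of compound 2.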